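A few compounds are considered here, and "the series" means these few. Any claim that something is new, unique, unknown or untested is made for them only; others in the source may bear on it.

Three compounds share a core in which a long chain ending in a phenyl ring is joined through a carbonyl to a five-membered aromatic ring, and each bears a different group on that ring. Compound 1 `COC(=O)c1ccccc1-c1cnc(C(=O)CCCCCCc2ccccc2)o1` gives 60 nM in an assay (Rattus norvegicus) for inhibition of Fatty-acid amide hydrolase 1 (Homo sapiens); on this read-out lower numbers stand for stronger inhibition and higher numbers for weaker inhibition. Compound 2 `O=C(CCCCCCc1ccccc1)c1ncc(-c2cccc(C(=O)C(F)(F)F)c2)o1` gives 16 nM in this assay. Compound 3 `Cc1cccnc1-c1cnc(C(=O)CCCCCCc2ccccc2)o1` gives 15 nM in this assay, the lowest of the three numbers, within the scatter of compound 2 and beyond the scatter from compound 1.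

Compound 4 `CSc1cnc(C(=O)CCCCCCc2ccccc2)o1` has not yet been measured in this assay. It differs from compound 3 in one place: methylsulfanyl in place of 3-methylpyridin-2-yl on an aromatic carbon. Among the compounds with values here, the three measured compounds all carry a six-membered aromatic ring at that position, and compound 4 carries none, so there is no step in the data that tests a change of this kind. He expects a weaker inhibitor, with a step of a 13-fold higher number from compound 3 to compound 4 (1.12 log units; beyond the scatter) that lies beyond the scatter. For compound 4 the estimated value in this assay is 200 nM, with a range from 50 nM to 800 nM.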

Compound 4, inhibition constant: 25 nM
The estimate for compound 4 lay 8.0-fold (0.90 log units) above the measured number, and the stated range ends above it.
By their numbers in this assay, from the lowest: compounds 3, 2 and 4 (each within the scatter of the next); then compound 1.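

Replacing 3-methylpyridin-2-yl with methylsulfanyl, on the aromatic carbon next to the ring oxygen, gives a 1.7-fold higher number from compound 3 to compound 4 (0.22 log units; within the scatter) in this assay and so stays within the scatter. The earlier compounds shown here all carried a six-membered aromatic ring at this position, and compound 4 now shows that, for this pair, a group with no ring can stand there without a step beyond the scatter. No measurement is available that accounts for this result.

Going by these compounds, whether this holds for other groups without a ring at this position, such as methoxy, ethylsulfanyl, an amine or a carboxylic acid, remains open. On these data alone, it is also open whether methylsulfanyl would give a similar number if the chain ending in a phenyl ring were shorter or longer.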